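The source may report more compounds than this note shows. Statements on the series, on what has been measured and on what is new or still open speak of the compounds shown alone.

Compound 1 `CC(C)(C)Cc1csc(N)c1C(=O)c1ccc(Cl)cc1` is the starting point of this step. In an assay on CHO cells for displacement of a labelled ligand from adenosine receptor A3 (Homo sapiens), read by scintillation counting, tested at 10 uM (on this read-out higher numbers stand for more inhibition at the one concentration tested (going by the name of the read-out) and lower numbers for less inhibition), compound 1 gives 5%. Two other compounds of the same core were measured alongside it: compound 2 `Cc1c(-c2ccccc2)sc(N)c1C(=O)c1ccc(Cl)cc1` gives 1% in this assay, and compound 3 `CC(C)(C)Cc1c(-c2ccccn2)sc(N)c1C(=O)c1ccc(Cl)cc1` gives 1%. Among the compounds with values here, of these three numbers the one for compound 1 is numerically the highest, yet its gaps to compound 2 and to compound 3 both lie within the scatter, so the three compounds are indistinguishable on this read-out.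

The new compound is compound 4 `CC(C)(C)Cc1c(-c2c(F)cccc2F)sc(N)c1C(=O)c1ccc(Cl)cc1`. Compared with compound 1 the change is 2,6-difluorophenyl in place of hydrogen on an aromatic carbon. Within the data shown here, the one measured step that bears on it puts an aromatic ring on the same carbon: a number 4 percentage points lower from compound 1 to compound 3 (within the scatter), a move that stayed within the scatter. Compound 4 is therefore expected to change by a number 2 percentage points lower from compound 1 to compound 4 (within the scatter) from compound 1, which is no step beyond the scatter. Compound 4 is estimated at 3%, between 0% and 12%.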

Compound 4, a percentage reported as inhibition, at one concentration (the size of the read-out at that concentration, not a potency): 1%
For compound 4 the middle estimate is 2 percentage points above the measured one; low and high end bracket the measured number.
By their numbers in this assay, from the lowest: compounds 2, 3, 4 and 1 (each within the scatter of the next).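

In this assay the change gives a number 4 percentage points lower from compound 1 to compound 4 (within the scatter) and so a phenyl ring carrying two fluorines, an aromatic ring of carbon only, now joins pyridin-2-yl as a second ring on this carbon next to the ring sulfur that leaves the number within the scatter. Exchanging one ring for the other gives no change at the digits printed from compound 3 to compound 4 (within the scatter) and so, at this position, the read-out does not separate pyridin-2-yl from 2,6-difluorophenyl. No measurement at hand explains why these numbers stay so close.

The compounds shown leave open whether a methyl group, a carboxylic acid or a ring bearing an amine on this carbon would move the number beyond the scatter. Also open, from the compounds shown here alone, is whether a longer chain in place of the neopentyl group would do so with 2,6-difluorophenyl kept on this carbon.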